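From (ethoxycarbonyl)amino to 2-carboxyethyl on the shared core

A few compounds are considered here, and "the series" means these few. Any claim that something is new, unique, unknown or untested is made for them only; others in the source may bear on it.

In a functional assay on HCT-116 cells (Homo sapiens) for inhibition, read by MTT assay, with a stated time of 72 h (a higher number here means a weaker inhibitor, a lower number a stronger inhibitor), compound 1 (`Cc1ccc(S(=O)(=O)n2c(C3(O)C=CC(=O)C=C3)cc3ccccc32)cc1`) gives 30 nM and compound 2 (`CCOC(=O)Nc1ccc(S(=O)(=O)n2c(C3(O)C=CC(=O)C=C3)cc3ccccc32)cc1`) gives 30 nM, so compound 2 stands level with compound 1. The next structure is compound 3 (`O=C1C=CC(O)(c2cc3ccccc3n2S(=O)(=O)c2ccc(CCC(=O)O)cc2)C=C1`), with 2-carboxyethyl in place of (ethoxycarbonyl)amino on an aromatic carbon, para to a large group: 2-carboxyethyl in place of (ethoxycarbonyl)amino on an aromatic carbon. Among the measured compounds shown here, only one measured step bears on this change, no change at the digits printed from compound 1 to compound 2 (within the scatter), and it exchanges the group at the same place. For the measured compounds named here, that step stays within the scatter, but no measured compound carries 2-carboxyethyl, so it gives only weak guidance. A modest loss in this assay is expected, though no change beyond the scatter remains possible. The estimated step is a 2.0-fold higher number from compound 2 to compound 3 (0.30 log units; within the scatter), toward a weaker inhibitor. For compound 3 the estimated value is 60 nM, within an expected range of 20 nM to 300 nM.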

Compound 3, half-maximal inhibitory concentration: 30 nM
Compound 3: the middle estimate sits 2.0-fold (0.30 log units) above what was measured, and the stated range covers the measured number.
By their numbers in this assay, from the lowest: compounds 1, 2 and 3 (each within the scatter of the next).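

Putting 2-carboxyethyl in place of (ethoxycarbonyl)amino on the aromatic carbon, para to a large group, gives no change at the digits printed from compound 2 to compound 3 (within the scatter) in this assay, so a chain ending in a carboxylic acid now stands level with the earlier groups at this place. Adding carboxymethyl on the saturated chain carbon bound to the aromatic carbon gives no change at the digits printed from compound 1 to compound 3 (within the scatter), so methyl, (ethoxycarbonyl)amino and 2-carboxyethyl show no step beyond the scatter among them. Nothing further is available here to explain this level result.

The three compounds leave open which groups at this place, if any, would move the number beyond the scatter. An amine at the end of the chain, a longer chain, or plain hydrogen in place of the whole group would test whether this level holds.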